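Compound 2 to compound 3: changing the carbonyl side chain

A few compounds are considered here, and "the series" means these few. Any claim that something is new, unique, unknown or untested is made for them only; others in the source may bear on it.

Going by the values given here, in a functional assay for inhibition, with Homo sapiens as the target (a higher number here means that more compound is needed for the effect, a lower number that less compound is needed), compound 2 (`CC(C)(CCl)C(=O)Nc1ccc(C2=NNC(=O)CC2)cc1`) gives 11.4 ug/mL, the only true number so far. Compound 1 (`O=C1CCC(c2ccc(NC(=O)CCCCl)cc2)=NN1`) gives > 46.4 ug/mL, which is a limit of the assay and not a number. The next compound is compound 3 (`CCCNCC(=O)Nc1ccc(C2=NNC(=O)CC2)cc1`), which carries (propylamino)methyl in place of 1-(chloromethyl)-1-methylethyl on a carbonyl carbon. Among the compounds with values here, one measured step bears on this place, an at least 4.0-fold lower number from compound 1 to compound 2 (0.60 log units; beyond the scatter), and it shows that this assay responds to a change of the group on that carbonyl carbon. That step swaps one chlorine-bearing group for another, so it gives no direct reading for (propylamino)methyl. Within the data shown here, compound 2 also has the only number so far, and a loss seems likelier than a gain. A moderate move towards a higher number is therefore expected, estimated as a 2.3-fold higher number from compound 2 to compound 3 (0.36 log units; beyond the scatter). For compound 3 the expected value is 26 ug/mL, with an estimated range of 8 ug/mL to 70 ug/mL.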

Compound 3, half-maximal effective concentration: about 46.4 ug/mL
For compound 3 the middle estimate is 1.8-fold (0.25 log units) below the measured one; the measured number falls inside the stated range.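

In this assay, going by these compounds alone, the change gives a 4.1-fold higher number from compound 2 to compound 3 (0.61 log units; beyond the scatter), the first direct reading of a chlorine-free group containing an amine on this carbonyl carbon. The leaving and entering groups match in heavy-atom count, yet compound 2 keeps the lowest number of the three, so this position responds to more than group size alone. The other new step gives a number no higher from compound 1 to compound 3 (the limit leaves the size open). Its size cannot be read, because the value of compound 1 is a limit and not a number: the limit of > 46.4 ug/mL in this assay, at which 1 of the 3 values shown sits.

From the compounds shown here alone, whether the rise tracks the loss of chlorine, the loss of branching or the entry of the amine stays open, as all three change together here. Going by these compounds, how a plain branched alkyl group, an ether or a carboxylic acid on this carbonyl carbon would read in this assay also remains open.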